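Two halogenated phenols in a macrocyclic depsipeptide series

The source may report more compounds than this note shows. Statements on the series, on what has been measured and on what is new or still open speak of the compounds shown alone.

Compound 1 `CC[C@H](C)[C@H]1C(=O)N[C@H](Cc2cc(Cl)c(O)c(Cl)c2)C(=O)N[C@@H](C(C)C)C(=O)O[C@H](c2ccccc2)[C@H](C)/C=C/C=C(\C)[C@H](OC)C/C=C(\C)C(=O)N1C` gives 137 nM in a functional assay on PANC-1 cells (Homo sapiens) for antiproliferative activity; a lower number here means a stronger inhibitor, a higher number a weaker inhibitor.
Compound 2 `CC[C@H](C)[C@H]1C(=O)N[C@H](Cc2ccc(O)c(Br)c2)C(=O)N[C@@H](C(C)C)C(=O)O[C@H](c2ccccc2)[C@H](C)/C=C/C=C(\C)[C@H](OC)C/C=C(\C)C(=O)N1C` gives 55.8 nM in this assay.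
Compound 3 `CC[C@H](C)[C@H]1C(=O)N[C@H](Cc2ccc(O)c(Br)c2)C(=O)N[C@@H](C(C)(C)O)C(=O)O[C@H](c2ccccc2)[C@H](C)/C=C/C=C(\C)[C@H](OC)C[C@H]2O[C@]2(C)C(=O)N1C` reaches only the assay limit of > 200 nM in this assay, which is a limit and not a number.

Compounds 1 and 2 share one core and differ by a single exchange, (3,5-dichloro-4-hydroxyphenyl in place of 3-bromo-4-hydroxyphenyl on a saturated chain carbon bound to a saturated ring carbon). That exchange is measured as a 2.5-fold higher number from compound 2 to compound 1 (0.39 log units; beyond the scatter), so the dichlorinated phenol gives the weaker inhibitor of the two.

Compound 3 has a different core; the difference between the core of compound 2 and the core of compound 3 is not broken down here. Its reading is described by the limit of > 200 nM in this assay, at which 1 of the 3 values shown sits.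

Compound 4 `CC[C@H](C)[C@H]1C(=O)N[C@H](Cc2cc(Cl)c(O)c(Cl)c2)C(=O)N[C@@H](C(C)(C)O)C(=O)O[C@H](c2ccccc2)[C@H](C)/C=C/C=C(\C)[C@H](OC)C[C@H]2O[C@]2(C)C(=O)N1C` carries the same kind of change on the core of compound 3: 3,5-dichloro-4-hydroxyphenyl in place of 3-bromo-4-hydroxyphenyl on a saturated chain carbon bound to a saturated ring carbon. Since the same exchange between compounds 2 and 1 raised the number, a further rise from compound 3 is expected, so compound 4 is expected to sit at or beyond the limit as well. The expected step is a step that the limit leaves unreadable from compound 3 to compound 4, resting on a 2.5-fold higher number from compound 2 to compound 1 (0.39 log units; beyond the scatter). Compound 4 is therefore estimated at 600 nM, with a range from 200 nM to 3000 nM.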

Compound 4, half-maximal inhibitory concentration: > 200 nM
Compound 4 was reported as a limit; the forecaster's own chance of this, stated with the estimate: 85%; the middle value is on the limit's open side.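

In this assay compound 4 gives > 200 nM, which is a limit and not a number. Compound 3 also has only a limit, so no step can be read from compound 3 to compound 4: the limit of > 200 nM in this assay, at which 2 of the 4 values shown sit.

The compounds shown leave open whether the exchange of phenols changes the number at all on this core.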